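The source may report more compounds than this note shows. Statements on the series, on what has been measured and on what is new or still open speak of the compounds shown alone.

Of the compounds shown here, three sharing one core have been measured in an assay on HEK293 cells for displacement of a labelled ligand from NPC1-like intracellular cholesterol transporter 1 (Homo sapiens); a lower number here means a stronger inhibitor, a higher number a weaker inhibitor. Compound 1 `CC(C)(C)OC(=O)NCC1CCCN(C(=O)CN2CN(c3ccccc3)C3(CCN(C(=O)c4ccc(C5CCCCC5)cc4)CC3)C2=O)C1` gives 3800 nM, compound 2 `CCC1CCCN(C(=O)CN2CN(c3ccccc3)C3(CCN(C(=O)c4ccc(C(C)(C)C)cc4)CC3)C2=O)C1` gives 3900 nM, and compound 3 `CS(=O)(=O)NCCNC(=O)CN1CN(c2ccccc2)C2(CCN(C(=O)c3ccc(C4CCCCC4)cc3)CC2)C1=O` gives 2100 nM. Compound 3 has the lowest of the three numbers, yet its gaps to compound 1 and to compound 2 both lie within the scatter, so the three cannot be told apart. Compound 4 `CCC1CCCN(C(=O)CN2CN(c3ccccc3)C3(CCN(C(=O)c4ccc(C5CCCCC5)cc4)CC3)C2=O)C1` differs from compound 3 in one place: 3-ethylpiperidin-1-yl in place of (2-(methanesulfonamido)ethyl)amino on a carbonyl carbon. Compound 2, which already carries the entering 3-ethylpiperidin-1-yl group, gives 3900 nM, a number within the scatter of compound 3. In this assay the step is therefore expected to be small, a 1.4-fold higher number from compound 3 to compound 4 (0.15 log units; within the scatter), a slight rise if anything beyond the scatter. Compound 4 is estimated at 3000 nM, in the range 1200 nM to 7500 nM.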

Compound 4, half-maximal inhibitory concentration: 2600 nM
Compound 4: the middle estimate sits 1.2-fold (0.06 log units) above what was measured; the range from low to high includes it.
By their numbers in this assay, from the lowest: compounds 3, 4, 1 and 2 (each within the scatter of the next).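

In this assay the change from (2-(methanesulfonamido)ethyl)amino to 3-ethylpiperidin-1-yl on a carbonyl carbon gives a 1.2-fold higher number from compound 3 to compound 4 (0.09 log units; within the scatter) so this position tolerates both groups, whether or not they carry hydrogen-bond donors and acceptors. Cyclohexyl in place of tert-butyl on an aromatic carbon gives a 1.5-fold lower number from compound 2 to compound 4 (0.18 log units; within the scatter) and methyl in place of (tert-butoxycarbonyl)amino on a saturated chain carbon gives a 1.5-fold lower number from compound 1 to compound 4 (0.16 log units; within the scatter) so neither of these changes moves the number beyond the scatter either. Nothing available explains these small steps. On these data alone, whether a carboxylic acid or a primary amine on that carbonyl carbon would move the number beyond the scatter remains open, as does the effect of a phenyl group in place of cyclohexyl on the aromatic carbon.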